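Amide substituent variation on the shared core

A few compounds are considered here, and "the series" means these few. Any claim that something is new, unique, unknown or untested is made for them only; others in the source may bear on it.

Measured in a functional assay on KARPAS-299 cells (Homo sapiens) for antiproliferative activity, read by MTT assay, with a stated time of 4 h; on this read-out lower numbers stand for stronger inhibition and higher numbers for weaker inhibition:
compound 1 `COC(=O)c1cccn1-c1ccc(Nc2ncc(Cl)c(Nc3ccccc3NS(C)(=O)=O)n2)c(OC)c1` gives 790 nM
compound 2 `CCN1CCN(C(=O)c2cccn2-c2ccc(Nc3ncc(Cl)c(Nc4ccccc4NS(C)(=O)=O)n3)c(OC)c2)CC1` gives 1410 nM

Compound 2 stands as the higher of the two numbers shown, but a 1.8-fold higher number from compound 1 to compound 2 (0.25 log units; within the scatter), so the two compounds are not separated by this assay. Compound 3 `COc1cc(-n2cccc2C(=O)N2CCCC2)ccc1Nc1ncc(Cl)c(Nc2ccccc2NS(C)(=O)=O)n1` is compound 2 with pyrrolidin-1-yl in place of 4-ethylpiperazin-1-yl on a carbonyl carbon. Among the compounds with values here, the only measured step that bears on this position is the exchange at the same carbonyl carbon, a 1.8-fold higher number from compound 1 to compound 2 (0.25 log units; within the scatter), where methoxy and 4-ethylpiperazin-1-yl returned numbers within the scatter of each other. On that evidence the carbonyl substituent has not yet moved the read-out, and no step beyond the scatter is expected for compound 3, the expected step being a 1.4-fold lower number from compound 2 to compound 3 (0.15 log units; within the scatter). Compound 3 is therefore estimated at 1000 nM, with a range from 400 nM to 2500 nM.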

Compound 3, half-maximal inhibitory concentration: 870 nM
Compound 3: the middle estimate sits 1.1-fold (0.06 log units) above what was measured; the measured number falls inside the stated range.
By their numbers in this assay, from the lowest: compounds 1, 3 and 2 (each within the scatter of the next).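

In this assay, the exchange of the larger ring for the smaller one at this carbonyl carbon gives a 1.6-fold lower number from compound 2 to compound 3 (0.21 log units; within the scatter), and pyrrolidin-1-yl in place of methoxy gives a 1.1-fold higher number from compound 1 to compound 3 (0.04 log units; within the scatter). Within the data shown here, the position now holds methoxy, 4-ethylpiperazin-1-yl and pyrrolidin-1-yl, and this read-out separates none of them, so the absence of a separation extends from the first exchange to a second cyclic amide and to the loss of the second ring nitrogen and the ethyl group. No evidence is available that would explain these results.

Going by these compounds, whether any substituent on this carbonyl carbon can move the read-out beyond the scatter remains open, and a carboxylic acid, an unsubstituted amide or a morpholine amide would each test this. The three compounds also share the rest of the core, so they leave open how far this result holds with changes elsewhere on it.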